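A few compounds are considered here, and "the series" means these few. Any claim that something is new, unique, unknown or untested is made for them only; others in the source may bear on it.

Compound 1 `CCCCCCCC/C=C\CCCCCCCCSCCC(=O)NCc1ccc(O)c(OC)c1` and compound 2 `CCCCCCCCCCCCCCCC(N)=O` have been measured in an assay on HEK293 cells for antagonist activity at transient receptor potential cation channel subfamily V member 2 (Rattus norvegicus), read by fluorescence and calcium flux, with a stated time of 5 min; on this read-out higher numbers stand for weaker inhibition and lower numbers for stronger inhibition; compound 3 `CCCCCCCCCCCCCCCCCCCC(N)=O` has not. In this assay compound 1 gives 2500 nM. For compound 2 the read-out is a limit rather than a number, > 10000 nM. For the measured compounds named here, compound 2 therefore stands at the limit of > 10000 nM in this assay, at which 1 of the 2 values shown sits, and the only numbered value in the set, that of compound 1, lies below that limit. The change from compound 2 to compound 3 is butyl in place of hydrogen on a saturated chain carbon, ten or more bonds along the chain from a carbonyl carbon. Going by the values given here, no step between measured compounds is available to size this change. Since compound 2 sits at the limit of > 10000 nM in this assay, at which 1 of the 2 values shown sits, a shift beyond the scatter in either direction is not expected. The expected step is a number no higher from compound 2 to compound 3 (the limit leaves the size open), with nothing beyond the scatter. Compound 3 is expected to give 10000 nM in this assay, within 3000 nM to 30000 nM, most likely again as a limit.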

Compound 3, half-maximal inhibitory concentration: > 10000 nM
Compound 3: no number, only a limit; the forecaster's own chance of this, stated with the estimate: 80%; the middle value lies on the limit itself.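

No step can be read from compound 2 to compound 3, as both read-outs in this assay are limits and not numbers: the limit of > 10000 nM in this assay, at which 2 of the 3 values shown sit. The compounds shown leave open whether butyl in place of hydrogen on this saturated chain changes inhibition at all.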